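This account rests on a few compounds, and the source may have more. Where it says the series, first, only, none or still open, it means among the compounds named here.

In an ADME assay on microsomes from liver (Mus musculus) for metabolic stability, read by LC-MS, using NADPH, with a stated time of 10 min, tested at 10 uM (on this read-out higher numbers stand for a longer-lived compound and lower numbers for a shorter-lived compound), compound 1 `Nc1ncnc2c1c(Oc1cc(C(F)(F)F)ccn1)nn2C1CCC1` gives 0.128 h, the second highest of the three numbers measured. Compound 2 `Nc1ncnc2c1c(Oc1cc(Cl)ccn1)nn2C1CCC1` gives 0.0617 h, and compound 3 `Nc1ncnc2c1c(Oc1cc(O)ccn1)nn2[C@H]1C[C@H](F)C1` gives 0.267 h. For the measured compounds named here, the only measured single change is a 2.1-fold lower number from compound 1 to compound 2 (0.32 log units; beyond the scatter), a swap on an aromatic carbon. Compound 4 `Nc1ncnc2c1c(Oc1cc(C(F)(F)F)ccn1)nn2[C@@H]1CCCC[C@H]1O` differs from compound 1 at a different place, on the aromatic nitrogen: 2-hydroxycyclohexyl in place of cyclobutyl on an aromatic nitrogen. Going by the values given here, no measured step touches this place, and compound 3 differs from compound 1 in two places at once, so it offers no single-change comparison either. With nothing in the data bearing on the change, no step beyond the scatter is expected in this assay in either direction, and the range is set wide. Compound 4 is therefore expected to give 0.14 h, between 0.06 h and 0.35 h, a step of a 1.1-fold higher number from compound 1 to compound 4 (0.04 log units; within the scatter).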

Compound 4, half-life: 1.1 h
Compound 4: middle estimate off by 7.9-fold (0.90 log units), on the low side, and the stated range ends below it.
By their numbers in this assay, from the lowest: compound 2; then compound 1; then compound 3; then compound 4.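

For the compounds shown here, this position on the aromatic nitrogen, untouched by the earlier steps, clearly affects the half-life: with 2-hydroxycyclohexyl in place of cyclobutyl, an 8.6-fold higher number from compound 1 to compound 4 (0.93 log units; beyond the scatter) appears in this assay and brings compound 4 to the top of the four numbers. The change alters ring size and adds a hydroxyl and two defined stereocentres at once, and this single step cannot separate these features. No measurement here explains the rise.

Plain cyclohexyl, without the hydroxyl, would help to separate ring from hydroxyl. As far as these compounds go, an amine in place of that hydroxyl, or the opposite arrangement at the two stereocentres, also remains open.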